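The source may hold more compounds than are shown below. What is called first, only, known or untested is meant among the compounds shown, and "the series" means these compounds.

Compound 1 `O=C(O)Cc1sc(C(c2ccccc2)c2ccccc2)nc1-c1ccccc1` gives 570 nM in an in vitro assay on HEK385-7 cells for displacement of a labelled ligand from prostaglandin D2 receptor 2 (Homo sapiens); on this read-out lower numbers stand for stronger inhibition and higher numbers for weaker inhibition. Compound 2 `N#Cc1ccc(-c2nc(C(c3ccc(F)cc3)c3ccc(F)cc3)sc2CC(=O)O)cc1` gives 150 nM in this assay.

Of the two numbers, compound 2 holds the lower one, and its gap to compound 1 lies beyond the scatter. Compound 3 `O=C(O)Cc1sc(C(c2ccc(F)cc2)c2ccc(F)cc2)nc1-c1ccnc(O)c1` has not yet been measured. It differs from compound 2 by 2-hydroxypyridin-4-yl in place of 4-cyanophenyl on an aromatic carbon. Going by the values given here, no measured pair shows this change, so its effect in this assay is unknown; a modest rise in the number, close to the edge of the scatter, is expected. The expected step is a 2.0-fold higher number from compound 2 to compound 3 (0.30 log units; within the scatter). Compound 3 is expected to give 300 nM, within a range from 80 nM to 1200 nM.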

Compound 3, half-maximal inhibitory concentration: 68 nM
For compound 3 the middle estimate is 4.4-fold (0.64 log units) above the measured one, outside the stated range (below it).
By their numbers in this assay, from the lowest: compound 3; then compound 2; then compound 1.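

Placing 2-hydroxypyridin-4-yl instead of 4-cyanophenyl on the aromatic carbon next to the ring nitrogen gives a 2.2-fold lower number from compound 2 to compound 3 (0.34 log units; beyond the scatter) in this assay as the read-out. Going by these compounds alone, this is the first comparison that isolates this position, and it shows that a ring with a hetero atom and a hydrogen-bond donor is accepted here without loss. No measurement available explains this gain.

The compounds shown leave open whether the hydroxy group or the ring nitrogen carries the step. As far as these compounds go, it also remains open how an amine in place of that hydroxy group would read.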